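The compounds below may be only part of what the source reports. "The series", "measured", "known", "first", "only" and "open" are said of these compounds alone.

Measured so far in a functional assay on MCF7 cells (Homo sapiens) for antiproliferative activity, read by MTT assay, with a stated time of 96 h; on this read-out lower numbers stand for stronger inhibition and higher numbers for weaker inhibition:
- compound 1, `O=C1NC(=O)C2(CSC3=C2C(=O)c2ncccc2C3=O)N1`: 120 nM
- compound 2, `O=C1C2=C(C(=O)c3ncccc31)C1(CS2)NC(=O)N(c2ccc([N+](=O)[O-])cc2)C1=O`: 350 nM
- compound 3, `O=C1NN(c2ccc([N+](=O)[O-])cc2)C(=O)C2(CSC3=C2C(=O)c2ncccc2C3=O)N1`: 550 nM

Compound 3 sits at the top of these three numbers, but its gap to compound 2 is within the scatter of this assay, and only its gap to compound 1 lies beyond it. Compound 4, `O=C1NN(c2ccc(Cl)cc2)C(=O)C2(CSC3=C2C(=O)c2ncccc2C3=O)N1`, is the next compound to be tested; compared with compound 3 it carries chloro in place of nitro on an aromatic carbon.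

Going by the values given here, no measured step covers this exchange. Among the compounds with values here, the one step recorded, a 2.9-fold higher number from compound 1 to compound 2 (0.46 log units; beyond the scatter), concerns putting a 4-nitrophenyl group onto a ring nitrogen, not the swap of one group for another on the phenyl ring, so it says nothing direct about compound 4. Compounds 2 and 3 share the 4-nitrophenyl group and give numbers within the scatter of each other, showing that the shared core tolerates that group on either nitrogen without a clear shift. With no guide for chloro against nitro, the safest expectation is a step of about no change at the digits printed from compound 3 to compound 4 (within the scatter), that is, nothing beyond the scatter. Compound 4 is therefore estimated at 550 nM, expected to fall between 250 nM and 1200 nM.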

Compound 4, half-maximal inhibitory concentration: 110 nM
Compound 4: middle estimate off by 5.0-fold (0.70 log units), on the high side, outside the stated range (below it).
By their numbers in this assay, from the lowest: compounds 4 and 1 (each within the scatter of the next); then compounds 2 and 3 (each within the scatter of the next).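

In this assay, going from 4-nitrophenyl to 4-chlorophenyl gives a 5.0-fold lower number from compound 3 to compound 4 (0.70 log units; beyond the scatter), so the group on this aromatic carbon, para to a large group, is not a silent spot. Going by these compounds alone, the earlier compounds showed only what happens when a whole 4-nitrophenyl group is added to the core, whereas this is the first change on the phenyl ring itself, and it alone moves the number beyond the scatter. Nothing shown here explains why chloro gives the lower number.

Going by these compounds, only these two groups are compared at this position, so it remains open how a methoxy group, an amine or a carboxylic acid there would fare. Also open, on these data alone, is whether the same exchange on compound 2, which carries its 4-nitrophenyl group on a different nitrogen, would give a step of similar size.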